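A few compounds are considered here, and "the series" means these few. Any claim that something is new, unique, unknown or untested is made for them only; others in the source may bear on it.

Compound 1 `CCCCCCCCNC(=O)[C@@H](NC(=O)c1ccco1)[C@@H](C)O`: 192000 nM
Compound 2 `CCCCCCCCCCCCCCCCCCNC(=O)[C@@H](NC(=O)c1ccco1)[C@@H](C)O`: 42300 nM

For the measured compounds named here, in a functional assay on HepG2 cells (Homo sapiens) for cytotoxicity, read by MTT assay, with a stated time of 48 h (on this read-out higher numbers stand for weaker inhibition and lower numbers for stronger inhibition), compound 2 stands lowest of the two numbers; the only step measured so far is a 4.5-fold lower number from compound 1 to compound 2 (0.66 log units; beyond the scatter), a change on the chain. Compound 3 `CCCCCCCCCCCCCCCCCCNC(=O)[C@@H](NC(=O)c1cc2ccccc2n1C)[C@@H](C)O` keeps that chain and changes the ring instead: 1-methyl-1H-indol-2-yl in place of furan-2-yl on a carbonyl carbon. Going by the values given here, no measured step touches this ring, so the chain step gives no guide here, and any expectation for this assay rests only on the neighbouring value of compound 2. The expected step is a 1.1-fold lower number from compound 2 to compound 3 (0.02 log units; within the scatter), with wide uncertainty. Compound 3 is estimated at 40000 nM, within 10000 nM to 160000 nM.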

Compound 3, half-maximal inhibitory concentration: > 200000 nM
Compound 3: no number, only a limit; the forecaster's own chance of this, stated with the estimate: 10%; middle value at least 5.0-fold (0.69 log units) from the limit.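

In this assay, replacing furan-2-yl with 1-methyl-1H-indol-2-yl on the carbonyl carbon gives an at least 4.7-fold higher number from compound 2 to compound 3 (0.67 log units; beyond the scatter), so the ring position also moves the read-out, and here the change weakens inhibition even with the long chain kept. Compound 3 has no exact number, only a limit: the limit of > 200000 nM in this assay, at which 1 of the 3 values shown sits. From the compounds shown here alone, the full size of this step therefore remains unknown.

The compounds shown cannot separate the effect of the added six-membered aromatic ring from that of the methyl. A phenyl ring or an unmethylated 1H-indol-2-yl group at this position would leave different parts of the change in place.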